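A few compounds are considered here, and "the series" means these few. Any claim that something is new, unique, unknown or untested is made for them only; others in the source may bear on it.

Compound 3 `CCN1C(=O)CSC1c1cccc(C(=O)NCCCCc2ccccc2)c1` gives 0% in a functional assay on MG-63 cells (Homo sapiens) for inhibition, read by CCK-8 assay, with a stated time of 72 h, tested at 1 uM (a higher number here means more inhibition at the concentration tested (going by the name of the read-out), a lower number less inhibition), the lowest of the three numbers, while compound 2 `COc1ccc(F)cc1N1C(=O)CSC1c1cccc(C(=O)NCCCCc2ccccc2)c1` gives 86% and compound 1 `COc1ccc(C)cc1N1C(=O)CSC1c1cccc(C(=O)NCCCCc2ccccc2)c1` gives 92% in this assay. Both lie far above compound 3: a number 92 percentage points lower from compound 1 to compound 3 (beyond the scatter) and a number 86 percentage points lower from compound 2 to compound 3 (beyond the scatter), whereas a number 6 percentage points lower from compound 1 to compound 2 (within the scatter). Compound 4 `COc1cccc(OC)c1N1C(=O)CSC1c1cccc(C(=O)NCCCCc2ccccc2)c1` carries 2,6-dimethoxyphenyl in place of ethyl on an amide-type nitrogen in a ring. This reverses the kind of change that removed nearly all inhibition in the two measured steps, so a large rise in this assay is expected for compound 4, of roughly the same order, with some uncertainty since the entering ring is not one of the two aryl groups already measured. Compound 4 is estimated at 80%, range 50% to 95%. The expected step is a number 80 percentage points higher from compound 3 to compound 4 (beyond the scatter).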

Compound 4, a percentage reported as inhibition, at one concentration (the size of the read-out at that concentration, not a potency): 80%
Beside the measured number, compound 4's estimate shows no gap at the digits printed, and the stated range covers the measured number.
By their numbers in this assay, from the lowest: compound 3; then compounds 4, 2 and 1 (each within the scatter of the next, the first and the last beyond it).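

In this assay, a third aryl group on the amide-type nitrogen also recovers the inhibition lost with ethyl (a number 80 percentage points higher from compound 3 to compound 4 (beyond the scatter)), so the recovery does not depend on either of the two earlier rings. Against 5-fluoro-2-methoxyphenyl the exchange stays small (a number 6 percentage points lower from compound 2 to compound 4 (within the scatter)), while against 2-methoxy-5-methylphenyl it costs a modest amount (a number 12 percentage points lower from compound 1 to compound 4 (beyond the scatter)). No available measurement accounts for these differences.

From the compounds shown here alone, whether this position needs an aromatic ring at all remains open, since cyclohexyl or a longer alkyl chain could be compared with ethyl. Unsubstituted phenyl would show whether methoxy contributes.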